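From Isobutyl to 4-Methoxyphenyl on a Shared Core

This account rests on a few compounds, and the source may have more. Where it says the series, first, only, none or still open, it means among the compounds named here.

Going by the values given here, in a functional assay on HL-60 cells (Homo sapiens) for cytotoxicity, read by MTT assay, with a stated time of 72 h (on this read-out lower numbers stand for stronger inhibition and higher numbers for weaker inhibition), compound 1 `COc1ccc(C(=O)n2c(CC(C)C)nc3ccccc32)cc1` gives 34 nM, the lowest of the three numbers so far. Compound 2 `COc1ccc(C(=O)n2c(C(C)C)nc3ccccc32)cc1` gives 630 nM, and compound 3 `COc1ccc(C(=O)n2c(C3CCCC3)nc3ccccc32)cc1` gives 76 nM. Compound 4 `COc1ccc(C(=O)n2c(-c3ccc(OC)cc3)nc3ccccc32)cc1` is not yet measured and carries 4-methoxyphenyl in place of isobutyl on an aromatic carbon. Two measured steps replace the same isobutyl: isopropyl gives a 19-fold higher number from compound 1 to compound 2 (1.27 log units; beyond the scatter), a large step, and cyclopentyl gives a 2.2-fold higher number from compound 1 to compound 3 (0.35 log units; beyond the scatter), a modest one. Neither puts an aromatic ring there, so they are only a loose guide. A higher number is still expected, with an estimated 7.4-fold higher number from compound 1 to compound 4 (0.87 log units; beyond the scatter). For compound 4, the estimated value is 250 nM, with an expected range from 40 nM to 2000 nM.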

Compound 4, half-maximal inhibitory concentration: 175 nM
Compound 4: the middle estimate sits 1.4-fold (0.15 log units) above what was measured; the measured number falls inside the stated range.
By their numbers in this assay, from the lowest: compound 1; then compound 3; then compound 4; then compound 2.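

The first aromatic ring at this position is not the worst group tried: a 3.6-fold lower number from compound 2 to compound 4 (0.56 log units; beyond the scatter), so 4-methoxyphenyl does better than isopropyl. It still falls behind both other groups, with a 5.1-fold higher number from compound 1 to compound 4 (0.71 log units; beyond the scatter) and a 2.3-fold higher number from compound 3 to compound 4 (0.36 log units; beyond the scatter), which leaves compound 4 third of the four.

Still open, on these data alone, is how much of this comes from the ring and how much from its methoxy group, which a plain phenyl would help to separate, and whether an amine or a carboxylic acid would be accepted on this carbon. Nothing available explains why the four groups fall in this order.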